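The source may report more compounds than this note shows. Statements on the series, on what has been measured and on what is new or still open speak of the compounds shown alone.

In a functional assay for inhibition, with Rattus norvegicus as the target (on this read-out lower numbers stand for stronger inhibition and higher numbers for weaker inhibition), compound 1 `COc1c(-c2ccccc2)c(-c2ccccc2)c(OC(C)=O)c2ccccc12` gives 11000 nM and compound 2 `CCOC(=O)c1c(-c2ccccc2)c(OC(C)=O)c2ccccc2c1OC` gives 5810 nM, so the two stand within the scatter of each other. Compound 3 `CCCCCc1c(C(=O)OCC)c(OC)c2ccccc2c1OC(C)=O` has not yet been measured. It differs from compound 2 by pentyl in place of phenyl on an aromatic carbon. Going by the values given here, only one measured step bears on this change, a 1.9-fold lower number from compound 1 to compound 2 (0.28 log units; within the scatter), where ethoxycarbonyl takes the place of phenyl on an aromatic carbon. That step also removes a phenyl and stays within the scatter, so no step beyond the scatter is expected in this assay. Among the compounds with values here, this is thin evidence, as no measured compound carries pentyl. The expected change is a 1.2-fold lower number from compound 2 to compound 3 (0.07 log units; within the scatter), which is no real shift. Compound 3 is estimated at 5000 nM, with an expected range from 1500 nM to 17000 nM.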

Compound 3, half-maximal inhibitory concentration: 940 nM
Compound 3: the middle estimate sits 5.3-fold (0.73 log units) above what was measured, outside the stated range (below it).
By their numbers in this assay, from the lowest: compound 3; then compounds 2 and 1 (each within the scatter of the next).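

In this assay the aromatic carbon ortho to an acetoxy group and ortho to an ethoxycarbonyl group proves responsive to its substituent: pentyl in place of phenyl there gives a 6.2-fold lower number from compound 2 to compound 3 (0.79 log units; beyond the scatter) and lies beyond the scatter, whereas replacing the other phenyl of compound 1 with ethoxycarbonyl gave only a 1.9-fold lower number from compound 1 to compound 2 (0.28 log units; within the scatter) and stayed within it. Losing a phenyl therefore does not leave the number unchanged at every position, and at this one no aromatic ring is needed for the lower number, since an open chain serves. Nothing available explains why this exchange lowers the number.

The compounds shown leave open whether the gain depends on chain length, as a propyl group or a longer chain could show. They also leave open whether a chain ending in an amine or a carboxylic acid would keep it.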